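Benzyl Exchanges and Cell Tolerance in a Shared Core

The source may report more compounds than this note shows. Statements on the series, on what has been measured and on what is new or still open speak of the compounds shown alone.

Compound 1, `Fc1cccc(F)c1Cn1ccc2nc(-c3ccccc3)nc-2c1`: > 100000 nM
Compound 2, `Cc1ccc(Cn2ccc3nc(-c4ccccc4)nc-3c2)cc1`: > 100000 nM
Compound 3, `Brc1ccccc1Cn1ccc2nc(-c3ccccc3)nc-2c1`: > 100000 nM

In an ADME assay on MDBK cells (Bos taurus) for cytotoxicity (a higher number here means that more compound is tolerated, a lower number that less compound is tolerated), compound 1 gives > 100000 nM, which is a limit of the assay rather than a number. Compound 2 gives > 100000 nM, again a limit. Compound 3 gives > 100000 nM, also a limit. Because all three values rest at the limit of > 100000 nM in this assay, at which 3 of the 3 values shown sit, the steps between them cannot be read: a step that the two limits leave unreadable from compound 1 to compound 2, a step that the two limits leave unreadable from compound 1 to compound 3 and a step that the two limits leave unreadable from compound 2 to compound 3. Compound 4, `Brc1ccc(Cn2ccc3nc(-c4ccccc4)nc-3c2)cc1`, differs from compound 1 in one place: 4-bromophenyl in place of 2,6-difluorophenyl on a saturated chain carbon bound to an aromatic nitrogen. The measured steps that exchange a group at the same place are those from compound 1 and carry no readable size. In this assay no step beyond the scatter is therefore expected, so the estimated step of a number no higher from compound 1 to compound 4 (the limit leaves the size open) is essentially flat. Compound 4 is expected to give about 100000 nM, between 50000 nM and 200000 nM, most probably again reported only as a limit.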

Compound 4, half-maximal cytotoxic concentration: 83000 nM
Beside the measured number, compound 4's estimate is 1.2-fold (0.08 log units) above it; measured number inside the range.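

In this assay, among these compounds, compound 4 is the first compound here to carry a number rather than a limit, which gives exchanges on the saturated chain carbon bound to an aromatic nitrogen a floor. The readable bounds are an at least 1.2-fold lower number from compound 1 to compound 4 (0.08 log units; that floor lies within the scatter) and an at least 1.2-fold lower number from compound 3 to compound 4 (0.08 log units; that floor lies within the scatter) and an at least 1.2-fold lower number from compound 2 to compound 4 (0.08 log units; that floor lies within the scatter), none of them beyond the scatter. Going by these compounds, their true sizes stay open, and the steps among compound 1, compound 2 and compound 3 cannot be read: the limit of > 100000 nM in this assay, at which 3 of the 4 values shown sit.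

The compounds shown leave open whether any exchange at this place moves the tolerated concentration beyond the scatter. They also leave open what an amine or a carboxylic acid in place of the bromo would do.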